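Trimming a Side Chain on Compound 2

The source may report more compounds than this note shows. Statements on the series, on what has been measured and on what is new or still open speak of the compounds shown alone.

Values in a functional assay on PC-3 cells (Homo sapiens) for antiproliferative activity, read by MTT assay, with a stated time of 48 h; a lower number here means a stronger inhibitor, a higher number a weaker inhibitor:
- compound 1 `CCn1c(C(=O)NCCN)ccc1C(CC)(CC)c1ccc(OCCC(O)(CC)CC)c(C)c1`: 2420 nM
- compound 2 `CCC(C)C(CO)NC(=O)c1ccc(C(CC)(CC)c2ccc(OCCC(O)(CC)CC)c(C)c2)n1CC`: 28400 nM

Compound 2 has the higher of the two numbers, 28400 nM, making it the weaker inhibitor. Compound 3 `CCn1c(C(=O)NC(C)CO)ccc1C(CC)(CC)c1ccc(OCCC(O)(CC)CC)c(C)c1` differs from it as follows: methyl in place of sec-butyl on a saturated chain carbon bound to an amide-type nitrogen and a saturated chain carbon, with methyl in place of sec-butyl. For the measured compounds named here, the only measured step that bears on this is a 12-fold higher number from compound 1 to compound 2 (1.07 log units; beyond the scatter), a large step beyond the scatter, made when 1-(hydroxymethyl)-2-methylbutyl replaced 2-aminoethyl. Compound 3 keeps part of that group, so a partial return in this assay seems likely, though no measurement tests this. The expected change is a 3.2-fold lower number from compound 2 to compound 3 (0.50 log units; beyond the scatter). For compound 3 the estimated value is 9000 nM, with an expected range of 2500 nM to 30000 nM.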

Compound 3, half-maximal inhibitory concentration: 7870 nM
The estimate for compound 3 lay 1.1-fold (0.06 log units) above the measured number; measured number inside the range.
By their numbers in this assay, from the lowest: compound 1; then compound 3; then compound 2.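

With the hydroxymethyl part kept, methyl in place of sec-butyl on this saturated chain carbon gives a 3.6-fold lower number from compound 2 to compound 3 (0.56 log units; beyond the scatter) in this assay, so the sec-butyl group alone accounts for part of the earlier loss. Removing it does not recover everything: 1-(hydroxymethyl)ethyl in place of 2-aminoethyl still gives a 3.3-fold higher number from compound 1 to compound 3 (0.51 log units; beyond the scatter). Nothing available explains either step.

Still open, going by these compounds, is where an ethyl group at this carbon would fall. Also open, on these data alone, is whether an amine in place of the hydroxyl of compound 3 would bring the number back toward that of compound 1.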